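The source may report more compounds than this note shows. Statements on the series, on what has been measured and on what is new or still open speak of the compounds shown alone.

In a functional assay on MDA-MB-231 cells (Homo sapiens) for antiproliferative activity, read by MTT assay, with a stated time of 72 h (a lower number here means a stronger inhibitor, a higher number a weaker inhibitor), compound 1 (`O=C(CCc1cccc2c1B(O)OC2)Nc1ccc(Br)cc1`) gives 5300 nM, while compound 2 (`CC(C)(C)c1ccc(NC(=O)CCc2cccc3c2B(O)OC3)cc1`) gives 33000 nM, the higher and so weaker of the two results so far. Compound 3 (`CCOC(=O)c1ccc(NC(=O)CCc2cccc3c2B(O)OC3)cc1`) has ethoxycarbonyl in place of tert-butyl on an aromatic carbon. Within the data shown here, only one measured step bears on this change, because it also involves tert-butyl: a 6.2-fold higher number from compound 1 to compound 2 (0.79 log units; beyond the scatter). With just that modest step as a guide, a step of similar or smaller size towards a lower number is expected in this assay. The expected change is a 2.8-fold lower number from compound 2 to compound 3 (0.44 log units; beyond the scatter). For compound 3 the estimated value is 12000 nM, with an expected range of 4000 nM to 35000 nM.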

Compound 3, half-maximal inhibitory concentration: > 100000 nM
Compound 3: no number, only a limit (the forecaster's own chance of this, stated with the estimate: 5%); middle value at least 8.3-fold (0.92 log units) away from the limit.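

In this assay, compound 3 reaches only a limit, not a number: the limit of > 100000 nM in this assay, at which 1 of the 3 values shown sits. Even so, ethoxycarbonyl brings an at least 3.0-fold higher number from compound 2 to compound 3 (0.48 log units; beyond the scatter), and the comparison with bromo shows an at least 18-fold higher number from compound 1 to compound 3 (1.27 log units; beyond the scatter). The choice of group at this position on the aromatic ring therefore matters more than the first two compounds showed, and among these three compounds, ethoxycarbonyl, the only group here with hydrogen-bond acceptors, gives the weakest result. As far as these compounds go, whether those acceptors matter, or the ethoxycarbonyl group as a whole, stays open, and a simple amine or a carboxylic acid here would help to separate these possibilities.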